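The source may report more compounds than this note shows. Statements on the series, on what has been measured and on what is new or still open speak of the compounds shown alone.

In a functional assay on MOLT-4 cells (Homo sapiens) for inhibition, read by sulforhodamine B assay, with a stated time of 48 h, tested at 10 uM (on this read-out lower numbers stand for less inhibition and higher numbers for more inhibition at the one concentration tested (going by the name of the read-out)), compound 1 `O=Cc1ccc(-c2cn3ccnc3c(-c3ccc4ncn(C5CCCCC5)c4c3)n2)cc1` gives 58.7%, and compound 2 `Fc1ccc(-c2cn3ccnc3c(-c3ccc4ncn(C5CCCCC5)c4c3)n2)cc1` gives 25.2%, the lowest of the two numbers shown; the change a number 33.5 percentage points lower from compound 1 to compound 2 (beyond the scatter) is the only measured step. Compound 3 `Clc1ccc(-c2cn3ccnc3c(-c3ccc4ncn(C5CCCCC5)c4c3)n2)cc1` differs from compound 2 by chloro in place of fluoro on an aromatic carbon. For the measured compounds named here, no measured step exchanges one halogen for another, so the one known step, which replaced formyl by fluoro and was large, bears on the present change only loosely: it shows that this assay can move strongly with a single change on that aromatic carbon, but it does not tell in which direction chloro would carry the number. The estimate therefore allows only a small step of a number 4.8 percentage points higher from compound 2 to compound 3 (within the scatter), within the scatter. Compound 3 is expected to give about 30%, between 10% and 55%.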

Compound 3, a percentage reported as inhibition, at one concentration (the size of the read-out at that concentration, not a potency): 8.87%
Compound 3: the middle estimate sits 21.1 percentage points above what was measured; measured number outside the range, below it.
By their numbers in this assay, from the lowest: compound 3; then compound 2; then compound 1.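

Within this assay, the exchange of one halogen for the other proves to matter on its own: going from 4-fluorophenyl to 4-chlorophenyl gives a number 16.3 percentage points lower from compound 2 to compound 3 (beyond the scatter) and so separates the two halogens at this aromatic carbon. The formyl compound stands further off, with a number 49.8 percentage points lower from compound 1 to compound 3 (beyond the scatter) showing the largest gap at this place, and the three compounds run chloro, fluoro, formyl from the lowest number to the highest. Nothing given here accounts for these differences.

On these data alone, whether an amine or a carboxylic acid on this aromatic carbon would bring the number close to that of compound 1 or leave it nearer that of compound 3 stays open. So does whether bromo would fall in line with the two halogens shown, and whether this order would hold on other cells.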